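The compounds below may be only part of what the source reports. "The series", "measured", "known", "first", "only" and "open" are said of these compounds alone.

Compound 1 `O=C(Nc1ccnc(C(F)(F)F)c1)Nc1ccnc(C(F)(F)F)c1` sits at the limit of < 7 uL/min in this assay, at which 1 of the 2 values shown sits, in an ADME assay on microsomes from liver (Homo sapiens) for metabolic stability, using NADPH, with a stated time of 60 min; a higher number here means faster removal of the compound, a lower number slower removal; compound 1 reports a limit there, < 7 uL/min, not a number. For the measured compounds named here, compound 2 `O=C(Nc1ccc(F)c(C(F)(F)F)c1)Nc1cnccn1` gives 210 uL/min in this assay, the only number in the set, so compound 2 is the only point of reference. Compound 3 `Cc1cc(NC(=O)Nc2ccc(F)c(C(F)(F)F)c2)on1` differs from compound 2 by 3-methyl-1,2-oxazol-5-yl in place of pyrazin-2-yl on an amide-type nitrogen. Going by the values given here, no measured step of this kind is available, so its size is unknown; the step from compound 2 to compound 3 is expected to stay within the scatter, a 1.2-fold lower number from compound 2 to compound 3 (0.07 log units; within the scatter). Compound 3 is estimated at 180 uL/min, with a range of 70 uL/min to 450 uL/min.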

Compound 3, intrinsic clearance in a liver preparation (reported as CLH), per the amount of preparation that the assay uses in the Homo sapiens assay: 73 uL/min
Compound 3: middle estimate off by 2.5-fold (0.39 log units), on the high side; low and high end bracket the measured number.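

For the compounds shown here, at this place, on an amide-type nitrogen, 3-methyl-1,2-oxazol-5-yl in place of pyrazin-2-yl gives the first readable step in the Homo sapiens assay: a 2.9-fold lower number from compound 2 to compound 3 (0.46 log units; beyond the scatter). In a physicochemical assay for lipophilicity, read by HPLC, measured as octanol-water partition, at pH 7.2 (a higher number here means a more lipophilic compound, a lower number a more polar compound), compound 2 reads 3 and compound 3 reads 3.2, values within the scatter of each other. Nothing at hand accounts for the step in removal.

Open, from the compounds shown here alone, is whether the five-membered ring or its methyl carries that step, and how an amine or a longer chain in place of the methyl would read in the Homo sapiens assay.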